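The compounds below may be only part of what the source reports. "The series", "measured", "known", "first", "only" and "open" are said of these compounds alone.

The measured compounds:

Compound 1, `Cn1cc(-c2cccc3c2CCC3c2ncc[nH]2)cn1`, in a functional assay on CHO cells for agonist activity at Alpha-1B adrenergic receptor (Homo sapiens), read by FLIPR and calcium flux (on this read-out lower numbers stand for an effect already at smaller amounts and higher numbers for an effect only at larger amounts of compound), gives > 10000 nM.
Compound 2, `CCS(=O)(=O)Nc1cccc(Cc2c[nH]cn2)c1`, in this assay gives > 10000 nM.
Compound 3, `CS(=O)(=O)Nc1c(Cl)ccc2c1CCCC2c1ncc[nH]1`, in this assay gives > 10000 nM.

Each of these three readings is a limit of the assay rather than a number. Compound 1 thus stands at the limit of > 10000 nM in this assay, at which 3 of the 3 values shown sit. Going by the values given here, compound 2 sits at that same limit, and so does compound 3, so no compound stands apart from the others, and no step between two measured compounds can be read from these values. Nothing in the measured set shows which structural change would move the reading off the limit.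

Compound 4, `c1cc(-c2ncco2)c2c(c1)C(c1ncc[nH]1)CC2`, has not yet been measured. It differs from compound 1 by 1,3-oxazol-2-yl in place of 1-methyl-1H-pyrazol-4-yl on an aromatic carbon. The rest of the shared core is unchanged.

Among the compounds with values here, with no measured step to lean on, the expectation rests only on where compound 1 stands. Because compound 1 sits at the limit of > 10000 nM in this assay, at which 3 of the 3 values shown sit, the step of a number no higher from compound 1 to compound 4 (the limit leaves the size open) is expected to be none beyond the scatter. Compound 4 is therefore expected to come out around 10000 nM, with a likely range from 3000 nM to 30000 nM, and most probably again as a limit rather than a number.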

Compound 4, half-maximal effective concentration: > 10000 nM
Compound 4: no number, only a limit; the forecaster's own chance of this, stated with the estimate: 80%; the middle value lies on the limit itself.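

Going by these compounds alone, compound 1 and compound 4 both end at a limit of the assay rather than at a number, so no step between them can be read in this assay. The compounds shown leave open whether any change in structure would bring a reading off that limit, since the whole set stands at one place: the limit of > 10000 nM in this assay, at which 4 of the 4 values shown sit.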